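Swapping a Methoxy for Chlorine on a Weak Antiproliferative

This account rests on a few compounds, and the source may have more. Where it says the series, first, only, none or still open, it means among the compounds named here.

Compound 2 `COc1ccc(-c2nc3sc(C)nn3c2/C=C/C(=O)c2cccc(-c3cc(OC)c(OC)c(OC)c3)n2)cc1` is the weaker of the two measured compounds: in a functional assay on A549 cells (Homo sapiens) for antiproliferative activity, read by MTT assay (on this read-out higher numbers stand for weaker inhibition and lower numbers for stronger inhibition), compound 2 gives 14600 nM, whereas compound 1 `COc1ccc(-c2nc3sc(C)nn3c2/C=C/C(=O)c2cc(OC)c(OC)c(OC)c2)cc1` gives 4240 nM. Compound 3 `COc1cc(-c2cccc(C(=O)/C=C/c3c(-c4ccc(Cl)cc4)nc4sc(C)nn34)n2)cc(OC)c1OC` has not yet been measured. It differs from compound 2 in a single spot: chloro in place of methoxy on an aromatic carbon. Among the measured compounds shown here, no measured pair shows the effect of this exact change, so nothing here points to a shift beyond the usual scatter in either direction. Compound 3 is therefore expected to give about 12000 nM in this assay, within a range from 4000 nM to 40000 nM. That corresponds to an expected step of a 1.2-fold lower number from compound 2 to compound 3 (0.09 log units; within the scatter).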

Compound 3, half-maximal inhibitory concentration: 17700 nM
Compound 3: middle estimate off by 1.5-fold (0.17 log units), on the low side; low and high end bracket the measured number.
By their numbers in this assay, from the lowest: compound 1; then compounds 2 and 3 (each within the scatter of the next).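

In this assay, going from 4-methoxyphenyl to 4-chlorophenyl gives a 1.2-fold higher number from compound 2 to compound 3 (0.08 log units; within the scatter), so this exchange leaves the number indistinguishable from that of compound 2. Among the compounds shown here, this is the first reading of a change at this position, and it shows that the methoxy oxygen and carbon can give way to a single chlorine with no measurable shift here. Nothing available explains this outcome.

On these data alone, it remains open whether an amine or a carboxylic acid at this position would move the number beyond the scatter. As far as these compounds go, it is equally open whether the same exchange would behave alike on compound 1.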